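Amide, urea and plain benzamide: cytotoxicity on one core

The source may hold more compounds than are shown below. What is called first, only, known or untested is meant among the compounds shown, and "the series" means these compounds.

Compound 1 `COc1cc(-c2nn(-c3cccc(NC(=O)c4ccc(Cl)c(C(F)(F)F)c4)c3)cc2-c2ccncc2)ccc1Cl` carries an aryl amide on the shared core. In a functional assay on BT-549 cells (Homo sapiens) for inhibition, read by sulforhodamine B assay, with a stated time of 48 h (on this read-out higher numbers stand for lower toxicity in this test and lower numbers for higher toxicity in this test), compound 1 gives only a limit, > 32500 nM. Compound 2 `COc1cc(-c2nn(-c3cccc(NC(=O)Nc4ccc(Cl)c(C(F)(F)F)c4)c3)cc2-c2ccncc2)ccc1Cl` differs in having the (4-chloro-3-(trifluoromethyl)phenyl)amino group on the carbonyl carbon, a urea. In this assay compound 2 likewise gives only a limit, > 32500 nM. Within the data shown here, the single measured step, a step that the two limits leave unreadable from compound 1 to compound 2, therefore cannot be sized. Among the measured compounds shown here, compound 2 thus stands at the limit of this assay, and the one other value shown is a limit as well (the limit of > 32500 nM in this assay, at which 2 of the 2 values shown sit).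

Compound 3 `COc1cc(-c2nn(-c3cccc(NC(=O)c4ccccc4)c3)cc2-c2ccncc2)ccc1Cl` is the unmeasured plain benzamide; the change from compound 2 is phenyl in place of (4-chloro-3-(trifluoromethyl)phenyl)amino on a carbonyl carbon. For the measured compounds named here, no readable step bears on this change: the only step measured is unreadable from both limits. Nothing in the data points to toxicity appearing with the smaller aryl group, so no step beyond the scatter is expected in either direction. In this assay compound 3 is expected at 32500 nM, in the range 10000 nM to 100000 nM, most likely again as a limit. The expected step of a number no higher from compound 2 to compound 3 (the limit leaves the size open) is accordingly one within the scatter.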

Compound 3, concentration lethal to 50% of the cells: > 100000 nM
Compound 3: a limit, no number; the forecaster's own chance of this, stated with the estimate: 70%; at least 3.0-fold (0.48 log units) between middle value and limit.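

In this assay compound 3 gives > 100000 nM, which is a limit and not a number. Among these compounds, compound 1 and compound 2 also stand only as limits, so no step among the three compounds can be read. The compounds shown leave open where the true value of any of them lies, so the groups on the carbonyl carbon remain unranked.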